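This account rests on a few compounds, and the source may have more. Where it says the series, first, only, none or still open, it means among the compounds named here.

Measured so far in a functional assay on HT-29 cells (Homo sapiens) for inhibition, read by sulforhodamine B assay, with a stated time of 48 h; a higher number here means a weaker inhibitor of growth, a lower number a stronger inhibitor of growth:
compound 1 `c1cc(OC2CCCC2)ccc1NC1=NCCO1`: 16100 nM
compound 2 `c1cc(NC2=NCCO2)cc(OC2CCCCC2)c1`: 4400 nM
compound 3 `O=C(CCl)NC(=O)Nc1ccc(-c2ccccc2)cc1`: 2300 nM

Compound 3 at 2300 nM cannot be separated from compound 2 at 4400 nM, as the gap lies within the scatter. The gap between compound 3 and compound 1 lies beyond the scatter, with compound 3 the stronger of that pair.

The next compound is compound 4 `O=C(CCl)NC(=O)Nc1ccc(OC2CCCCC2)cc1`, which carries cyclohexyloxy in place of phenyl on an aromatic carbon of compound 3 (cyclohexyloxy in place of phenyl on an aromatic carbon). Among the compounds with values here, no measured pair isolates this change, so the expectation rests on thin evidence. Compound 2 also carries a cyclohexyloxy group and gives 4400 nM, but its core differs from that of compound 3. Nothing here points to a large shift in this assay. The expected step of a 1.3-fold higher number from compound 3 to compound 4 (0.12 log units; within the scatter) is slightly upward and stays within the scatter. For compound 4 the estimated value is 3000 nM, with an expected range of 1100 nM to 8000 nM.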

Compound 4, concentration for 50% growth inhibition: 3100 nM
Compound 4: the middle estimate sits 1.0-fold (0.01 log units) below what was measured, and the stated range covers the measured number.
By their numbers in this assay, from the lowest: compounds 3, 4 and 2 (each within the scatter of the next); then compound 1.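

In this assay, within the data shown here, the position para to a group of 8 heavy atoms accepts cyclohexyloxy in place of phenyl with a 1.3-fold higher number from compound 3 to compound 4 (0.13 log units; within the scatter), the first step that isolates a single change. At this position, therefore, a six-membered aromatic ring of carbon only and a six-membered non-aromatic ring attached through oxygen cannot be told apart by growth inhibition, even though the entering group adds a hydrogen-bond acceptor. No measured property of either group is available to interpret this step.

As far as these compounds go, whether an amine, a carboxylic acid or a short methoxy group at this position would give a number beyond the scatter remains open. Also open, from the compounds shown here alone, is whether the same exchange would behave alike on a different core.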